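Reversed amide on the benzylamine arm of compound 1

This account rests on a few compounds, and the source may have more. Where it says the series, first, only, none or still open, it means among the compounds named here.

Three analogues sharing one core carry a substituted amine on the core and differ in the group attached to that amine. Compound 1, `CNc1nc(NCc2ccc(NC(C)=O)cc2)cc(-c2ccccn2)n1`, gives in a functional assay on HEK293 cells for agonist activity at G-protein coupled receptor 39 (Homo sapiens), read by inositol phosphate accumulation (a higher number here means that more compound is needed for the effect, a lower number that less compound is needed), a value of 5 nM, the lowest of the three numbers. Compound 2, `CNc1nc(NC2(c3ccc(Cl)cc3)CCC2)cc(-c2ccccn2)n1`, gives 25 nM, a step beyond the scatter above compound 1. Compound 3, `CNc1nc(NCc2ccncc2)cc(-c2ccccn2)n1`, gives 87 nM, further still from compound 1 and also beyond the scatter. No pair among these three differs in only one place, so no single-change step is available from the measured set.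

Compound 4, `CNC(=O)c1ccc(CNc2cc(-c3ccccn3)nc(NC)n2)cc1`, has the same atoms as compound 1 joined differently: methylcarbamoyl in place of acetamido on an aromatic carbon. The change sits on an aromatic carbon of a six-membered aromatic ring of carbon only, para to a large group. Both groups carry one hydrogen-bond donor and one hydrogen-bond acceptor; what changes is the order in which carbonyl and amide nitrogen meet the ring.

Nothing measured here separates the two amide orientations, so the expectation rests on compound 1 alone. The step of a 2.0-fold higher number from compound 1 to compound 4 (0.30 log units; within the scatter) is expected to be small, toward a somewhat higher number, and possibly within the scatter. Compound 4 is estimated at 10 nM, with a range from 3 nM to 40 nM.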

Compound 4, half-maximal effective concentration: 30 nM
Beside the measured number, compound 4's estimate is 3.0-fold (0.48 log units) below it, within the range that was stated.
By their numbers in this assay, from the lowest: compound 1; then compounds 2 and 4 (each within the scatter of the next); then compound 3.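

The amide orientation on this aromatic carbon, para to a large group, is not interchangeable in this assay since methylcarbamoyl in place of acetamido gives a 6.0-fold higher number from compound 1 to compound 4 (0.78 log units; beyond the scatter) even though both groups have the same heavy atoms and the same hydrogen-bond donor and acceptor counts. Among the compounds shown here, the earlier compounds offered no single-change step, so this is the first direct reading at this position; it shows that the order in which carbonyl and amide nitrogen meet the ring is enough on its own to move the number beyond the scatter, with acetamido giving the lower number of the two. No measurement available here bears on why the two orientations differ.

Open, from the compounds shown here alone, is how a primary carboxamide, a methanesulfonamide or a urea would read on the same aromatic carbon, and so whether methylcarbamoyl and acetamido mark the two ends of what this position allows or only two points within it. Equally open, going by these compounds, is whether a longer acyl chain such as propionamido keeps the number of compound 1 or moves it, and whether the same reversal would give a step of similar size on another amine arm.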